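The source may report more compounds than this note shows. Statements on the series, on what has been measured and on what is new or still open speak of the compounds shown alone.

Measured so far:
- compound 1 `NS(=O)(=O)c1ccc(NC(=S)Nc2ccc3ncnc(Nc4cccc(Cl)c4F)c3c2)cc1`: 25100 nM
- compound 2 `Cc1ccc(Nc2ncnc3ccc(NC(=S)Nc4ccc(S(N)(=O)=O)cc4)cc23)cc1`: 39400 nM

Both compounds were tested in a functional assay on NCI-H1975 cells (Homo sapiens) for antiproliferative activity, read by MTT assay, with a stated time of 72 h (on this read-out higher numbers stand for weaker inhibition and lower numbers for stronger inhibition), and compound 2 carries the higher of the two numbers. That position rests on little, since the step of a 1.6-fold higher number from compound 1 to compound 2 (0.20 log units; within the scatter) is within the scatter, so the two compounds cannot be told apart on this read-out. The unmeasured compound 3 `CCc1ccc(Nc2ncnc3ccc(NC(=S)Nc4ccc(S(N)(=O)=O)cc4)cc23)cc1` differs from compound 2 by methyl in place of hydrogen on a saturated chain carbon bound to an aromatic carbon. Going by the values given here, the one measured step, a 1.6-fold higher number from compound 1 to compound 2 (0.20 log units; within the scatter), exchanged the whole aryl group on the nitrogen and did not move the number beyond the scatter; no measured step concerns growing the chain on that aryl group, so there is no direct guide. On this basis compound 3 is expected to stay close to compound 2, with the estimated step of a 1.1-fold lower number from compound 2 to compound 3 (0.05 log units; within the scatter) and no change beyond the scatter. The estimate for compound 3 in this assay is 35000 nM, within a range of 14000 nM to 90000 nM.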

Compound 3, half-maximal inhibitory concentration: 38700 nM
Estimate against measurement, compound 3: 1.1-fold (0.04 log units) below, within the range that was stated.
By their numbers in this assay, from the lowest: compounds 1, 3 and 2 (each within the scatter of the next).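

Extending the methyl of compound 2 to the ethyl of compound 3 leaves the two compounds indistinguishable in this assay (a 1.0-fold lower number from compound 2 to compound 3 (0.01 log units; within the scatter)). Going by these compounds alone, this is the first measured change to the chain on this aryl group, and it shows that one added carbon there does not separate the compounds on this read-out. Compound 3 also cannot be told apart from the halogenated compound 1 (a 1.5-fold higher number from compound 1 to compound 3 (0.19 log units; within the scatter)), so 3-chloro-2-fluorophenyl, 4-methylphenyl and 4-ethylphenyl on that nitrogen all give similar numbers, and no supporting evidence bears on this result.

The compounds shown leave open whether a propyl chain, an amine or a carboxylic acid in place of the ethyl would shift the number beyond the scatter. They also leave open whether changing the rest of the molecule would do so.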